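This account rests on a few compounds, and the source may have more. Where it says the series, first, only, none or still open, it means among the compounds named here.

Working notes on the series. Of the compounds shown here, two in the set have been measured. Compound 1 `COc1cc(Cl)c(Nc2nc(Cl)cn([C@@H](COCCF)C3CC3)c2=O)c(Cl)c1` and compound 2 `Cc1cc(C#N)cc(Cl)c1Nc1nc(Cl)cn([C@@H](COCCF)C2CC2)c1=O` share one core and differ only in the aryl ring attached through the amine. In an assay on frontal cortex for displacement of a labelled ligand from corticotropin-releasing factor receptor 1 (Rattus norvegicus), with a stated time of 2 h (a lower number here means a stronger inhibitor, a higher number a weaker inhibitor), compound 1 gives 0.6 nM, and in this assay compound 2 gives 4.5 nM. Compound 2 thus has the higher of the two numbers; its nearest neighbour is compound 1, whose lower number lies beyond the usual scatter of the measurement.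

Compound 3 `Cc1cc(C#N)cc(C)c1Nc1nc(Cl)cn([C@@H](COCCF)C2CC2)c1=O` has not been measured. It differs from compound 2 in one place: methyl in place of chloro on an aromatic carbon. Among the compounds with values here, no measured pair in the set shows this exchange, so its size must be judged from the change itself. Chloro and methyl are each a single heavy atom, neither carries a donor or acceptor, and neither bears a charge. The expectation is therefore a change in either direction no larger than the scatter, with the step from compound 2 to compound 3 estimated at a 1.1-fold higher number from compound 2 to compound 3 (0.05 log units; within the scatter). For compound 3 in this assay the estimated value is 5 nM, within a range of 2 nM to 15 nM.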

Compound 3, half-maximal inhibitory concentration in the corticotropin-releasing factor receptor 1 assay: 7.4 nM
Estimate against measurement, compound 3: 1.5-fold (0.17 log units) below; low and high end bracket the measured number.
By their numbers in the corticotropin-releasing factor receptor 1 assay, from the lowest: compound 1; then compounds 2 and 3 (each within the scatter of the next).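

In the corticotropin-releasing factor receptor 1 assay, with methyl in place of chloro on an aromatic carbon, ortho to a large group, compound 3 gives 7.4 nM, the series' first reading of this exchange: a 1.6-fold higher number from compound 2 to compound 3 (0.22 log units; within the scatter) at a position that holds either group without a step beyond the scatter. In a physicochemical assay for lipophilicity, using the shake flask method, in phosphate buffer, measured as octanol-water partition, with a stated time of 40 min, at pH 7.4 (on this read-out lower numbers stand for lower lipophilicity and higher numbers for higher lipophilicity), compound 2 gives 3.7 and compound 3 gives 3.4. In the physicochemical assay the same exchange shows a number 0.30 log units lower from compound 2 to compound 3 (within the scatter) and so, on both read-outs, compound 2 and compound 3 cannot be told apart. Nothing on hand accounts for either step or shows what chloro or methyl does at this position.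

Only chloro and methyl appear at this position in the compounds shown, so it remains open whether an ethyl group, a methoxy group, a trifluoromethyl group or an amine would stay within the same range of numbers or mark a limit on what the position holds. A single matched pair also leaves open whether this exchange would give a similar step on an aryl ring carrying other groups, and compound 1 has no partner in the set that differs from it in one place.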